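Replacing 5-phenyl-1,3-thiazol-2-yl with 4-methylphenyl

The compounds below may be only part of what the source reports. "The series", "measured", "known", "first", "only" and "open" are said of these compounds alone.

Compound 1 `CCOC(=O)C1=C(NN=C(C(C)=O)C(C)=O)Nc2[nH]nc(C)c2C1c1ccc(N(C)C)cc1` gives 9740 nM
Compound 2 `CCOC(=O)C1=C(N/N=C(\C#N)C(N)=O)Nc2[nH]nc(C)c2C1c1ccc(N(C)C)cc1` gives 50100 nM
Compound 3 `CCOC(=O)C1=C(N/C=N/c2ncc(-c3ccccc3)s2)Nc2[nH]nc(C)c2C1c1ccc(N(C)C)cc1` gives 10100 nM

These three compounds share one core and differ in the group on an amine nitrogen. In a functional assay on MCF7 cells (Homo sapiens) for inhibition, read by MTT assay, with a stated time of 48 h (on this read-out higher numbers stand for weaker inhibition and lower numbers for stronger inhibition), compound 3 (10100 nM) holds the second highest of the three numbers. It lies within the usual scatter of compound 1 (9740 nM), while compound 2 (50100 nM) reads clearly higher.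

Compound 4 `CCOC(=O)C1=C(N/C=N/c2ccc(C)cc2)Nc2[nH]nc(C)c2C1c1ccc(N(C)C)cc1` has not yet been measured. It differs from compound 3 by one change (4-methylphenyl in place of 5-phenyl-1,3-thiazol-2-yl on a double-bonded nitrogen), with 4-methylphenyl in place of 5-phenyl-1,3-thiazol-2-yl on a double-bonded nitrogen. Going by the values given here, the one measured step that bears on this is modest (a 5.1-fold higher number from compound 1 to compound 2 (0.71 log units; beyond the scatter)), and it involves other groups. Among the compounds with values here, it shows only that a swap in this part of the molecule can move the number beyond the scatter. Compound 1 (9740 nM) and compound 3 (10100 nM) carry very different groups, yet their values stay within the scatter of each other. Within the data shown here, no measured pair compares the two groups exchanged here, so no direction is supported, and no step beyond the scatter is expected in this assay. The expected step is small (a 1.3-fold higher number from compound 3 to compound 4 (0.11 log units; within the scatter)). For compound 4 the estimated value is 13000 nM (expected range 4500 nM to 38000 nM).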

Compound 4, half-maximal inhibitory concentration: 50500 nM
The estimate for compound 4 lay 3.9-fold (0.59 log units) below the measured number; measured number above the stated range.
By their numbers in this assay, from the lowest: compounds 1 and 3 (each within the scatter of the next); then compounds 2 and 4 (each within the scatter of the next).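

Going by these compounds alone, on the double-bonded nitrogen, the choice of aromatic group does matter in this assay: 4-methylphenyl in place of 5-phenyl-1,3-thiazol-2-yl gives a clear loss of inhibition (a 5.0-fold higher number from compound 3 to compound 4 (0.70 log units; beyond the scatter)), the first direct comparison of these two groups. Within the data shown here, measured against the non-ring groups on the amine nitrogen, the group carrying 4-methylphenyl also reads weaker than the one in the first compound (a 5.2-fold higher number from compound 1 to compound 4 (0.71 log units; beyond the scatter)) but cannot be told apart from the one in the second (a 1.0-fold higher number from compound 2 to compound 4 (0.00 log units; within the scatter)), so very different groups can share a similar reading at this site, at the weak end as well as at the stronger end. Nothing measured here explains why the two aromatic groups differ.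

The compounds shown leave open whether the difference follows the thiazole ring, the extra phenyl ring or the methyl group, as a plain phenyl or an unsubstituted 1,3-thiazol-2-yl on this nitrogen would help to separate these parts. As far as these compounds go, it also remains open how a 4-aminophenyl, a 4-carboxyphenyl or a pyridine ring would read in this place.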